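Pyridine N-oxide on the amide side chain: expected plasma binding

The source may report more compounds than this note shows. Statements on the series, on what has been measured and on what is new or still open speak of the compounds shown alone.

Measured compounds:
Compound 1 `C[C@@H](NC(=O)c1cc(-c2ccc(F)cn2)cc(C(C)(C)O)c1)c1ccc(C(F)(F)F)[n+]([O-])c1`: 55.3%
Compound 2 `Cc1ccc(-c2cc(C(=O)N[C@H](C)c3ccc(C(F)(F)F)nc3)cc(-c3ncccc3F)c2)nc1`: 98.6%
Compound 3 `Cc1ccc(-c2cc(C(=O)N[C@H](C)c3ccc(C(F)(F)F)nc3)cc(C(C)(C)O)c2)nc1`: 95.2%

In an ADME assay on a cell-free system (plasma, Rattus norvegicus) for protein binding, compound 2 gives 98.6%, the lowest unbound fraction among the three measured compounds. Among the compounds with values here, the one measured step, a 3.4-fold higher unbound fraction from compound 2 to compound 3 (0.54 log units; beyond the scatter), shows that changing the group on the aromatic ring of the shared core shifts binding moderately. Within the data shown here, compound 1, with 55.3%, differs from compound 3 in two places and from compound 2 in three, so no single step can be drawn from it; its two values with compound 3 merely show a far higher unbound fraction for compound 1.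

Compound 4 `Cc1ccc(-c2cc(C(=O)N[C@H](C)c3ccc(C(F)(F)F)[n+]([O-])c3)cc(-c3ncccc3F)c2)nc1` differs from compound 2 only in the side chain: a group of 11 heavy atoms (6 carbon, 1 nitrogen, 1 oxygen, 3 fluorine; one six-membered aromatic ring with 1 hetero atom) in place of a group of 10 heavy atoms (6 carbon, 1 nitrogen, 3 fluorine; one six-membered aromatic ring with 1 hetero atom), on a saturated chain carbon bound to an amide-type nitrogen and a saturated chain carbon. Among the measured compounds shown here, the enters group carries one more oxygen on the ring nitrogen; no measured step isolates this change, though compound 1, the only other compound carrying it, sits well apart from the others. Compound 4 is therefore expected to show a moderately higher unbound fraction, estimated as a 5.0-fold higher unbound fraction from compound 2 to compound 4 (0.70 log units; beyond the scatter), giving an expected 93% (range 82% to 97.5%).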

Compound 4, plasma protein binding: 95.2%
Compound 4: middle estimate off by 1.5-fold (0.16 log units) (unbound fraction), on the high side; the range from low to high includes it.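

In this assay, within the data shown here, one more oxygen on the ring nitrogen of the 6-(trifluoromethyl)pyridin-3-yl group gives a 3.4-fold higher unbound fraction from compound 2 to compound 4 (0.54 log units; beyond the scatter), so this change now has a measured step of its own, which no earlier pair offered. The step lies beyond the scatter, yet compound 4 at 95.2% remains mostly bound to plasma protein. Compound 1 also carries this oxygen but differs from compound 4 in more than one place, so its value cannot be set against this step.

No measurement available here explains the size of the step. As far as these compounds go, it remains open whether the oxygen gives a similar step when 1-hydroxy-1-methylethyl replaces 3-fluoropyridin-2-yl, and how an amine or a carboxylic acid in place of the 6-(trifluoromethyl)pyridin-3-yl group would behave.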